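Pyridin-2-yl amide on the pyrazole core

The compounds below may be only part of what the source reports. "The series", "measured", "known", "first", "only" and "open" are said of these compounds alone.

In an assay on CHO cells with metabotropic glutamate receptor 5 (Homo sapiens) as the target (on this read-out higher numbers stand for an effect only at larger amounts of compound and lower numbers for an effect already at smaller amounts), compound 3 `Cc1ccc(C(=O)Nc2cc(-c3ccccc3)nn2-c2ccccc2)cc1` gives 30 nM and stands second highest of the three measured numbers. Compound 2 `O=C(Nc1cc(-c2ccccc2)nn1-c1ccccc1)c1ccc(F)c(F)c1` gives 10 nM; the step of a 3.0-fold higher number from compound 2 to compound 3 (0.48 log units; beyond the scatter) is modest but beyond the scatter. Compound 1 `O=C(Nc1ccc(Br)cc1CN1C(=O)c2ccccc2C1=O)c1ccccn1`, built on a different core, gives 740 nM, a much higher number than compound 3 shows. Compound 4 `O=C(Nc1cc(-c2ccccc2)nn1-c1ccccc1)c1ccccn1` carries the change (pyridin-2-yl in place of 4-methylphenyl on a carbonyl carbon). For the measured compounds named here, no measured step covers this particular swap; the only step on the carbonyl substituent, from compound 2 to compound 3, shows that this position moves the number modestly. Compound 4 is therefore expected to stay near compound 3, with the step of a 1.3-fold higher number from compound 3 to compound 4 (0.12 log units; within the scatter) estimated to be small, and its value is estimated at 40 nM, between 10 nM and 160 nM.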

Compound 4, half-maximal effective concentration: 290 nM
The estimate for compound 4 lay 7.3-fold (0.86 log units) below the measured number, outside the stated range (above it).
By their numbers in this assay, from the lowest: compound 2; then compound 3; then compound 4; then compound 1.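

Pyridin-2-yl on the carbonyl carbon gives a 9.7-fold higher number from compound 3 to compound 4 (0.99 log units; beyond the scatter) against 4-methylphenyl and a 29-fold higher number from compound 2 to compound 4 (1.46 log units; beyond the scatter) against 3,4-difluorophenyl in this assay on the shared core, so this position can move the number further than the earlier step showed. For the compounds shown here, of the three groups seen here, the only one with a ring nitrogen carries the highest number, though three compounds set no rule. The compounds shown leave open whether pyridin-3-yl or pyridin-4-yl would read like pyridin-2-yl at this place, and how a saturated piperidin-4-yl would read. Nothing available here gives a reason for the rise.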